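From a 4-fluorophenyl to a 3,4-dimethylphenyl sulfonamide

A few compounds are considered here, and "the series" means these few. Any claim that something is new, unique, unknown or untested is made for them only; others in the source may bear on it.

compound 1 `CCc1ccccc1NS(=O)(=O)c1ccc(N2CCNC2=O)cc1` gives 240 nM
compound 2 `Cc1cccc(NS(=O)(=O)c2ccc(N3CCNC3=O)cc2)c1` gives 110 nM
compound 3 `O=C1NCCN1c1ccc(S(=O)(=O)Nc2ccc(F)cc2)cc1` gives 370 nM

These three numbers come from a functional assay on HT-29 cells (Homo sapiens) for antiproliferative activity, read by sulforhodamine B assay, with a stated time of 48 h (a lower number here means a stronger inhibitor, a higher number a weaker inhibitor), and the compounds differ only in the group on a sulfonamide nitrogen. Compound 3 (370 nM) sits within the scatter of its nearest neighbour (a 1.5-fold higher number from compound 1 to compound 3 (0.19 log units; within the scatter)) but clearly apart from the remaining one (a 3.4-fold higher number from compound 2 to compound 3 (0.53 log units; beyond the scatter)). The next compound, compound 4 `Cc1ccc(NS(=O)(=O)c2ccc(N3CCNC3=O)cc2)cc1C`, keeps the shared core and changes that group (3,4-dimethylphenyl in place of 4-fluorophenyl on a sulfonamide nitrogen), with 3,4-dimethylphenyl in place of 4-fluorophenyl.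

The step that bears most on this change is the one between the 3-methylphenyl of compound 2 and the 4-fluorophenyl of compound 3 (a 3.4-fold higher number from compound 2 to compound 3 (0.53 log units; beyond the scatter)), read backwards. The step involving the 2-ethylphenyl of compound 1 (a 2.2-fold lower number from compound 1 to compound 2 (0.34 log units; beyond the scatter)) shows that this series moves only modestly with such swaps. Going by the values given here, no measured compound carries two methyl groups, so the comparison is indirect. A modest move to a lower number in this assay is therefore expected, somewhat smaller than the full gap seen with compound 2. The expected move is a 2.3-fold lower number from compound 3 to compound 4 (0.36 log units; beyond the scatter) (an estimate, not a measurement). Compound 4 is estimated at 160 nM (expected range 70 nM to 350 nM).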

Compound 4, half-maximal inhibitory concentration: 230 nM
Beside the measured number, compound 4's estimate is 1.4-fold (0.16 log units) below it, within the range that was stated.
By their numbers in this assay, from the lowest: compound 2; then compounds 4, 1 and 3 (each within the scatter of the next).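

In this assay, putting 3,4-dimethylphenyl in place of 4-fluorophenyl on a sulfonamide nitrogen gives a 1.6-fold lower number from compound 3 to compound 4 (0.21 log units; within the scatter) and so does not separate the two compounds. The new information lies in the single added methyl: methyl in place of hydrogen on an aromatic carbon gives a 2.1-fold higher number from compound 2 to compound 4 (0.32 log units; beyond the scatter) as a modest step, so within these compounds a second methyl on the aromatic ring does not extend the gain seen with the 3-methylphenyl group. Swapping 2-ethylphenyl for 3,4-dimethylphenyl gives a 1.0-fold lower number from compound 1 to compound 4 (0.02 log units; within the scatter) and leaves those two groups indistinguishable here, while compound 2 now stands as the strongest of the four, with its steps to all the others beyond the scatter.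

The compounds shown leave open whether a methoxy group, a chlorine or an amine on the aromatic ring would move the number beyond the scatter, and whether a propyl chain in place of the single methyl of compound 2 would hold its standing. Nothing given here accounts for any of these steps.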